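Ester chain length and tolerated concentration on Vero cells

The source may report more compounds than this note shows. Statements on the series, on what has been measured and on what is new or still open speak of the compounds shown alone.

Compound 1 `CC(C)COC(=O)C(O)Cn1cnc2c(N)ncnc21` is the starting point. In a functional assay on Vero cells (Chlorocebus sabaeus) for cytotoxicity (a lower number here means that less compound is tolerated, a higher number that more compound is tolerated), compound 1 gives > 400 ug/mL, which is a limit of the assay rather than a number. Two close relatives are known. Compound 2 `Nc1ncnc2c1ncn2CC(O)C(=O)OCCO` gives > 400 ug/mL in this assay, also a limit. Compound 3 `CCOC(=O)C(O)Cn1cnc2c(N)ncnc21` gives > 400 ug/mL, again a limit. The new compound 4 `CCCCCOC(=O)C(O)Cn1cnc2c(N)ncnc21` differs from compound 1 in one place: butyl in place of isopropyl on a saturated chain carbon bound to an oxygen next to a carbonyl group. The steps a step that the two limits leave unreadable from compound 1 to compound 2 and a step that the two limits leave unreadable from compound 1 to compound 3 are the closest guides, since both also change the group on a saturated chain carbon bound to an oxygen next to a carbonyl group; their size is unreadable because of the limit of > 400 ug/mL in this assay, at which 3 of the 3 values shown sit. No direction can be read for the new step. For compound 4 the expected step is a number no higher from compound 1 to compound 4 (the limit leaves the size open). Compound 4 is estimated at 400 ug/mL, within 200 ug/mL to 800 ug/mL, most likely reported once more as a limit.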

Compound 4, minimum cytotoxic concentration: 200 ug/mL
Compound 4: middle estimate off by 2.0-fold (0.30 log units), on the high side; measured number inside the range.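

At this position, butyl in place of isopropyl gives the first actual number rather than a limit in this assay. The result gives an at least 2.0-fold lower number from compound 1 to compound 4 (0.30 log units; that floor lies within the scatter), an at least 2.0-fold lower number from compound 3 to compound 4 (0.30 log units; that floor lies within the scatter) and an at least 2.0-fold lower number from compound 2 to compound 4 (0.30 log units; that floor lies within the scatter). Each step is only a floor, and its true size stays unknown because the other compounds sit at a limit: the limit of > 400 ug/mL in this assay, at which 3 of the 4 values shown sit.

On these data alone, whether compound 4 truly differs from the others therefore remains open. Also open, as far as these compounds go, is how the number would respond to a longer chain, such as hexyl, or to an amine or a carboxylic acid at this place.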